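Sulfonamide nitrogen substituents on a thiourea-linked quinoline core

The source may report more compounds than this note shows. Statements on the series, on what has been measured and on what is new or still open speak of the compounds shown alone.

Compound 1 `N=C(N)NS(=O)(=O)c1ccc(N/C(S)=N\c2ccnc3cc(C(F)(F)F)ccc23)cc1` carries a guanidine-type group on the sulfonamide nitrogen of the shared core. Among the measured compounds shown here, in a functional assay on HT-1080 cells (Homo sapiens) for antiproliferative activity, read by sulforhodamine B assay, with a stated time of 48 h (a lower number here means a stronger inhibitor, a higher number a weaker inhibitor), compound 1 gives 24300 nM, the lower of the two numbers so far, with compound 2 `COc1cc(NS(=O)(=O)c2ccc(N/C(S)=N\c3ccnc4cc(C(F)(F)F)ccc34)cc2)nc(OC)n1` giving 29500 nM in this assay. For the measured compounds named here, the one measured step, a 1.2-fold higher number from compound 1 to compound 2 (0.08 log units; within the scatter), swaps the same small group for an aromatic dimethoxy-bearing ring and stays within the scatter.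

Compound 3 `COc1ncnc(NS(=O)(=O)c2ccc(N/C(S)=N\c3ccnc4cc(C(F)(F)F)ccc34)cc2)c1OC` differs from compound 1 as follows: a group of 10 heavy atoms (6 carbon, 2 nitrogen, 2 oxygen; one six-membered aromatic ring with 2 hetero atoms) in place of a group of 3 heavy atoms (1 carbon, 2 nitrogen; no ring), on a sulfonamide nitrogen. The entering 5,6-dimethoxypyrimidin-4-yl group is a ring-positional variant of what enters in compound 2, so the step to compound 2 is the only one that bears on this change, and it was flat. No step beyond the scatter is therefore expected; compound 3 is estimated at 27000 nM, with a range of 12000 nM to 60000 nM, which corresponds to an expected step of a 1.1-fold higher number from compound 1 to compound 3 (0.05 log units; within the scatter).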

Compound 3, half-maximal inhibitory concentration: 22800 nM
The estimate for compound 3 lay 1.2-fold (0.07 log units) above the measured number; low and high end bracket the measured number.
By their numbers in this assay, from the lowest: compounds 3, 1 and 2 (each within the scatter of the next).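

Changing the dimethoxypyrimidine isomer on the sulfonamide nitrogen leaves the result in this assay unchanged within the scatter (a 1.3-fold lower number from compound 2 to compound 3 (0.11 log units; within the scatter)), so this pair shows no readable dependence on where the methoxy groups sit on this ring. Exchanging the small group of compound 1 for the 5,6-dimethoxypyrimidin-4-yl group is also flat (a 1.1-fold lower number from compound 1 to compound 3 (0.03 log units; within the scatter)), so the flat result of the earlier ring exchange holds for a second dimethoxypyrimidine isomer. No available measurement bears on the reason for this flatness.

The three compounds leave open whether any group on this nitrogen can move the number beyond the scatter. A plain hydrogen, an acetyl group, a phenyl ring without methoxy groups or a saturated morpholine ring would each test that.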